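A few compounds are considered here, and "the series" means these few. Any claim that something is new, unique, unknown or untested is made for them only; others in the source may bear on it.

Compound 1, `Cc1nnc(SCC(=O)c2ccc(Cl)cc2)n1N1C(=O)c2ccccc2C1=O`, in a functional assay on PC-3M cells (Homo sapiens) for cytotoxicity, read by MTT assay, with a stated time of 48 h (on this read-out higher numbers stand for weaker inhibition and lower numbers for stronger inhibition), gives > 200000 nM, which is a limit of the assay.
Compound 2, `C=CCSc1nnc(CC)n1N1C(=O)c2ccccc2C1=O`, gives in this assay the value > 200000 nM, again a limit.
Compound 3, `C=CCSc1nnc(CCC)n1N1C(=O)c2ccccc2C1=O`, gives in this assay the value > 200000 nM, also a limit.

Compound 3 therefore stands at the limit of the assay, as do the other two values shown (the limit of > 200000 nM in this assay, at which 3 of the 3 values shown sit). Among the measured compounds shown here, the one step between measured compounds that differ in one place, the step from compound 2 to compound 3 a step that the two limits leave unreadable from compound 2 to compound 3, lies between two limits and its size cannot be read.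

Compound 4, `CCCc1nnc(SCC(=O)c2ccc(Cl)cc2)n1N1C(=O)c2ccccc2C1=O`, differs from compound 3 by (4-chlorophenyl)carbonyl in place of vinyl on a saturated chain carbon bound to a sulfur. For the measured compounds named here, no measured step bears readably on this change. Compound 1 carries the same (4-chlorophenyl)carbonyl group on the carbon bound to sulfur and sits at the limit, and compound 3 sits at the limit; what lies between them is not known.

With every value shown being a limit, compound 4 is expected to sit at the limit as well, so the step from compound 3 to compound 4 is estimated as a step that the limit leaves unreadable from compound 3 to compound 4. For compound 4 in this assay the estimate is 250000 nM, ranging from 100000 nM to 1000000 nM.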

Compound 4, half-maximal inhibitory concentration: > 200000 nM
Compound 4 ended at the assay's limit; the forecaster's own chance of this, stated with the estimate: 85%; the middle value lies beyond the limit too.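

Neither new step, from compound 3 to compound 4 or from compound 1 to compound 4, can be read, because both ends of each step are limits and not numbers: the limit of > 200000 nM in this assay, at which 4 of the 4 values shown sit.

The compounds shown leave open whether any of them has a measurable potency in this assay, and whether changing the allyl, ((4-chlorophenyl)carbonyl)methyl or alkyl groups alters it.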